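Naphthalene in place of methoxyphenyl on a triazole arylpiperazine

A few compounds are considered here, and "the series" means these few. Any claim that something is new, unique, unknown or untested is made for them only; others in the source may bear on it.

Compound 2 `COc1ccccc1-c1cn(CCC(O)CN2CCN(c3ccccc3OC)CC2)nn1` is the parent of this step. In an assay on HEK293 cells for displacement of a labelled ligand from D(4) dopamine receptor (Homo sapiens), read by scintillation counting, with a stated time of 1 h (on this read-out lower numbers stand for stronger inhibition and higher numbers for weaker inhibition), compound 2 gives only a limit, > 3000 nM. Its neighbour compound 1 `COc1ccccc1N1CCN(CC(O)CCn2cc(-c3ccc4ncccc4c3)nn2)CC1` also returns only a limit in this assay, > 3000 nM. The step that the two limits leave unreadable from compound 1 to compound 2 cannot be read, since both ends sit at the same limit (the limit of > 3000 nM in this assay, at which 2 of the 2 values shown sit). The new compound 3 `COc1ccccc1N1CCN(CC(O)CCn2cc(-c3ccc4ccccc4c3)nn2)CC1` carries a naphthalen-2-yl in place of 2-methoxyphenyl on an aromatic carbon. Among the compounds with values here, no measured step bears directly on this change, and the two values shown give no direction: they only show that neither compound 1 nor compound 2 reached a readable number. Compound 3 is therefore expected to stay weak, with an estimated step that the limit leaves unreadable from compound 2 to compound 3 that is not readable against the scatter. The estimate for compound 3 in this assay is 4000 nM, with a range from 1000 nM to 15000 nM.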

Compound 3, inhibition constant: > 2000 nM
Compound 3: a limit, no number; the forecaster's own chance of this, stated with the estimate: 65%; the middle value is on the limit's open side.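

In this assay compound 3 gives only a limit, > 2000 nM, and the steps to it from compound 1 and compound 2 cannot be read. As far as these compounds go, how quinolin-6-yl, 2-methoxyphenyl and naphthalen-2-yl rank against one another in this assay stays open, as does a readable number for any of the three compounds.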